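A few compounds are considered here, and "the series" means these few. Any claim that something is new, unique, unknown or untested is made for them only; others in the source may bear on it.

In a functional assay on SU-DHL-6 cells (Homo sapiens) for antiproliferative activity, read by MTT assay (a higher number here means a weaker inhibitor, a lower number a stronger inhibitor), compound 1 (`COc1ncc(-c2ccc3ncnc(N[C@H]4CCCN(C(=O)CCBr)C4)c3c2)cc1C#N`) gives 15 nM, compound 2 (`COc1ncc(-c2ccc3ncnc(N[C@H]4CCCN(C(=O)C5CCN(C)CC5)C4)c3c2)cc1C#N`) gives 420 nM and compound 3 (`COc1ncc(-c2ccc3ncnc(N[C@H]4CCCN(C(=O)c5cccnc5)C4)c3c2)cc1C#N`) gives 120 nM, the second highest of the three numbers. Compound 4 (`CCOC(=O)CN1CCC[C@H](Nc2ncnc3ccc(-c4cnc(OC)c(C#N)c4)cc23)C1`) carries (ethoxycarbonyl)methyl in place of (pyridin-3-yl)carbonyl on an amine nitrogen in a ring. The measured steps all exchange one group on a carbonyl carbon for another: a 28-fold higher number from compound 1 to compound 2 (1.45 log units; beyond the scatter), an 8.0-fold higher number from compound 1 to compound 3 (0.90 log units; beyond the scatter) and a 3.5-fold lower number from compound 2 to compound 3 (0.54 log units; beyond the scatter). None of them takes the carbonyl off that ring nitrogen, so they offer only a rough guide to size, and a modest rise in the number is expected. The expected change is a 2.5-fold higher number from compound 3 to compound 4 (0.40 log units; beyond the scatter). Compound 4 is estimated at 300 nM, with an expected range of 70 nM to 1200 nM.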

Compound 4, half-maximal inhibitory concentration: 500 nM
Estimate against measurement, compound 4: 1.7-fold (0.22 log units) below, within the range that was stated.
By their numbers in this assay, from the lowest: compound 1; then compound 3; then compounds 2 and 4 (each within the scatter of the next).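

Compound 4 is the only compound shown without a carbonyl directly on the amine nitrogen in the ring, and in this assay the exchange for (ethoxycarbonyl)methyl gives a 4.2-fold higher number from compound 3 to compound 4 (0.62 log units; beyond the scatter). Its number cannot be told apart from that of the (1-methylpiperidin-4-yl)carbonyl group, with a 1.2-fold higher number from compound 2 to compound 4 (0.08 log units; within the scatter), while the (2-bromoethyl)carbonyl group remains far ahead, with a 33-fold higher number from compound 1 to compound 4 (1.52 log units; beyond the scatter). Nothing available explains these steps.

The compounds shown leave open how a carboxylic acid in place of the ethyl ester would read on this nitrogen. They also leave open whether a plain propanoyl group would keep the number of compound 1 without the bromine.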